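Difluoropiperidine for methylpiperazine on two quinazoline hydroxamates

The compounds below may be only part of what the source reports. "The series", "measured", "known", "first", "only" and "open" are said of these compounds alone.

Three compounds were examined in an assay on isolated protein for inhibition of protein deacetylase HDAC6 (Homo sapiens), tested at 0.5 uM; on this read-out higher numbers stand for more inhibition at the one concentration tested (going by the name of the read-out) and lower numbers for less inhibition. Compound 1 `CN1CCN(c2nc(-c3ccc(C(=O)NO)cc3)nc3ccccc23)CC1` gives 89.4%. Compound 2 `O=C(NO)c1ccc(-c2nc(N3CCC(F)(F)CC3)c3ccccc3n2)cc1` gives 71.7%, and compound 3 `COc1cc(OC)c2c(N3CCN(C)CC3)nc(-c3ccc(C(=O)NO)cc3)nc2c1` gives 78.3%. The difference between the core of compound 1 and the core of compound 3 is not broken down here.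

One change is made twice. From compound 1 to compound 2 it is 4,4-difluoropiperidin-1-yl in place of 4-methylpiperazin-1-yl on an aromatic carbon, and it produced a number 17.7 percentage points lower from compound 1 to compound 2 (beyond the scatter). Compound 4 `COc1cc(OC)c2c(N3CCC(F)(F)CC3)nc(-c3ccc(C(=O)NO)cc3)nc2c1`, not yet measured, carries the same kind of change relative to compound 3: 4,4-difluoropiperidin-1-yl in place of 4-methylpiperazin-1-yl on an aromatic carbon. The surroundings are not word for word the same: in compound 1 the place is described as meta to a large group, whereas in compound 3 it is meta to a 4-(hydroxycarbamoyl)phenyl group, ortho to a fused ring and meta to a fused ring.

Resting on the step seen in compound 1 and compound 2, a number 17.7 percentage points lower from compound 1 to compound 2 (beyond the scatter), compound 4 is expected to show a similar loss, estimated as a number 17.3 percentage points lower from compound 3 to compound 4 (beyond the scatter). Compound 4 is therefore estimated at 61%, with the likely range from 46% to 75%.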

Compound 4, a percentage reported as inhibition, at one concentration (the size of the read-out at that concentration, not a potency): 53.2%
For compound 4 the middle estimate is 7.8 percentage points above the measured one, within the range that was stated.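

In this assay, the same replacement, 4,4-difluoropiperidin-1-yl in place of 4-methylpiperazin-1-yl on an aromatic carbon, gives a number 25.1 percentage points lower from compound 3 to compound 4 (beyond the scatter), so the loss seen on the first core appears on the second as well, and the two steps cannot be told apart: the same change on two cores in this assay, a number 17.7 percentage points lower (beyond the scatter) from compound 1 to compound 2 and a number 25.1 percentage points lower (beyond the scatter) from compound 3 to compound 4, 7.4 percentage points apart, within the scatter of two such steps Within this pair of cores, then, the step carries over in direction and, as far as the scatter allows, in size. Going by these compounds alone, this rests on only two matched pairs at one concentration, so it does not show that the step would hold on other cores, and it does not explain why the replacement lowers the read-out.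

The compounds shown leave open whether a morpholine or an unsubstituted piperidine at the same place would behave like the 4-methylpiperazin-1-yl compounds or like the 4,4-difluoropiperidin-1-yl compounds. They also leave open how a single methoxy group on the shared core would bear on the step.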